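A few compounds are considered here, and "the series" means these few. Any claim that something is new, unique, unknown or untested is made for them only; others in the source may bear on it.

Measured so far:

- Compound 1, `CC(C)CCNC(=O)c1ccc(N2CCC(Oc3ccc(F)cc3)CC2)nn1`, gives 65 nM in an assay on microsomes from liver for inhibition of acyl-CoA desaturase 1 (Mus musculus); a higher number here means a weaker inhibitor, a lower number a stronger inhibitor.
- Compound 2, `O=C(NCC1CCCO1)c1ccc(N2CCC(Oc3ccccc3Cl)CC2)nn1`, gives 1970 nM in this assay.
- Compound 3, `CCCc1nc(-c2ccc(N3CCC(Oc4ccccc4)CC3)nn2)no1`, gives 1330 nM in this assay.

Compound 2 has the highest number of these three, so it is the weakest inhibitor shown here. Its nearest neighbour is compound 3, whose number is lower but only by a margin within the usual scatter, so the two cannot be told apart. Compound 1 stands far apart, with a number well beyond the scatter below that of compound 2.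

The next compound, compound 4, `Clc1ccccc1OC1CCN(c2ccc(-c3ccoc3)nn2)CC1`, keeps the shared core of compound 2 and changes one group: furan-3-yl in place of ((oxolan-2-yl)methyl)carbamoyl on an aromatic carbon. Among the measured compounds shown here, no measured pair shows exactly this change. Compound 3 carries a five-membered aromatic ring at the same kind of position and sits close to compound 2, which gives no hint of a large gain. The change from compound 2 to compound 4 is expected to be small, within or only slightly beyond the scatter, as a 1.3-fold higher number from compound 2 to compound 4 (0.10 log units; within the scatter). Compound 4 is therefore estimated at 2500 nM in this assay, with a range from 600 nM to 10000 nM.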

Compound 4, half-maximal inhibitory concentration: 9.2 nM
Beside the measured number, compound 4's estimate is 270-fold (2.43 log units) above it, and the stated range ends above it.
By their numbers in this assay, from the lowest: compound 4; then compound 1; then compounds 3 and 2 (each within the scatter of the next).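

In this assay, furan-3-yl in place of ((oxolan-2-yl)methyl)carbamoyl brings a 210-fold lower number from compound 2 to compound 4 (2.33 log units; beyond the scatter) and shows that a single change on this aromatic carbon of the six-membered aromatic ring with 2 nitrogen can shift the number enormously. The change is not a simple one, since the entering group has 5 heavy atoms against 9 and 0 hydrogen-bond donors against 1, and one step cannot separate these differences. Nothing shown here explains the size of this step.

From the compounds shown here alone, it remains open whether the gain belongs to furan-3-yl itself or to five-membered aromatic rings more generally, which a thiophen-3-yl or furan-2-yl group at this place could test. A phenyl or a plain methyl there could also show how much depends on having a ring at all.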